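Ethynyl for Butyl Repeated on the Bromo Analogue

This account rests on a few compounds, and the source may have more. Where it says the series, first, only, none or still open, it means among the compounds named here.

Compound 1 `CCCCCNc1nc(SC)nc(CCO)c1Cl` is the reference point of this small set. In an ADME assay on Vero cells (Chlorocebus sabaeus) for cytotoxicity, with a stated time of 48 h (on this read-out higher numbers stand for lower toxicity in this test and lower numbers for higher toxicity in this test), compound 1 gives 108000 nM. Compound 2 `C#CCNc1nc(SC)nc(CCO)c1Cl` carries ethynyl in place of butyl on a saturated chain carbon bound to a nitrogen on an aromatic ring and in this assay compound 2 gives 485000 nM; the change made a 4.5-fold higher number from compound 1 to compound 2 (0.65 log units; beyond the scatter). Compound 3 `CCCCCNc1nc(SC)nc(CCO)c1Br` differs from compound 1 by bromo in place of chloro on an aromatic carbon, and in this assay compound 3 gives 93300 nM, a move of a 1.2-fold lower number from compound 1 to compound 3 (0.06 log units; within the scatter).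

Compound 4 `C#CCNc1nc(SC)nc(CCO)c1Br` has not been measured. It stands to compound 3 as compound 2 stands to compound 1: the change is ethynyl in place of butyl on a saturated chain carbon bound to a nitrogen on an aromatic ring, and the place description is the same word for word in both pairs, so it is the same change on a core that differs only by the bromo for chloro exchange. That exchange gave a step within the scatter between compound 1 and compound 3, so the author expects the step from compound 3 to compound 4 to be about a 4.5-fold higher number from compound 3 to compound 4 (0.65 log units; beyond the scatter), resting on a 4.5-fold higher number from compound 1 to compound 2 (0.65 log units; beyond the scatter) that compound 1 and compound 2 showed. The author therefore estimates that compound 4 will give around 420000 nM, expected to fall between 200000 nM and 900000 nM.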

Compound 4, half-maximal cytotoxic concentration: 827000 nM
The estimate for compound 4 lay 2.0-fold (0.29 log units) below the measured number; measured number inside the range.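

On the bromo core, ethynyl in place of butyl on a saturated chain carbon bound to a nitrogen on an aromatic ring gave an 8.9-fold higher number from compound 3 to compound 4 (0.95 log units; beyond the scatter) in this assay, and this step and the one on the chloro core do not differ beyond the scatter: the same change on two cores in this assay, a 4.5-fold higher number (0.65 log units; beyond the scatter) from compound 1 to compound 2 and an 8.9-fold higher number (0.95 log units; beyond the scatter) from compound 3 to compound 4, 2.0-fold (0.30 log units) apart, within the scatter of two such steps

The bromo for chloro exchange, read on the ethynyl-bearing pair, gave a 1.7-fold higher number from compound 2 to compound 4 (0.23 log units; within the scatter), and it too agrees with its earlier counterpart: the same change on two cores in this assay, a 1.2-fold lower number (0.06 log units; within the scatter) from compound 1 to compound 3 and a 1.7-fold higher number (0.23 log units; within the scatter) from compound 2 to compound 4, 2.0-fold (0.30 log units) apart, within the scatter of two such steps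

The four compounds thus show the two changes carrying over between these two cores in this one test, but they do not show any real difference in the size of either step from one core to the other, nor that the pattern holds on any other core.

The compounds shown leave open whether a shorter saturated chain such as ethyl, or a phenyl group, in place of the ethynyl would give a similar number. They also leave open whether fluoro or a nitrile in place of the halogen would leave the number where it stands.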